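The source may report more compounds than this note shows. Statements on the series, on what has been measured and on what is new or still open speak of the compounds shown alone.

Compound 1, `O=S(=O)(NCCCCCCNCc1ccc(Br)cc1)c1cccc(C(F)(F)F)c1`, compound 2, `O=S(=O)(NCCCCCCNCc1ccc(Br)cc1)c1c(Cl)cccc1Cl`, and compound 3, `O=S(=O)(NCCCCCCNCc1ccc(Br)cc1)c1c(Cl)cc(C(F)(F)F)cc1Cl`, share one core and differ only in the substitution pattern of the aryl sulfonyl ring. In a functional assay on MIA PaCa-2 cells (Homo sapiens) for inhibition, read by MTT assay, with a stated time of 72 h (a lower number here means a stronger inhibitor of growth, a higher number a weaker inhibitor of growth), compound 1 gives 5970 nM. In this assay compound 2 gives 14700 nM, and compound 3 gives 5670 nM. The difference between the cores of compound 1 and compound 2 is not broken down here. Compound 3 arises from compound 2 by trifluoromethyl in place of hydrogen on an aromatic carbon, and that change brought a 2.6-fold lower number from compound 2 to compound 3 (0.41 log units; beyond the scatter). Compound 1 and compound 3 stand within the scatter of each other, so no order is claimed between them, while compound 2 sits beyond the scatter from both.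

Compound 4, `O=S(=O)(NCCCCCCNCc1ccc(Br)cc1)c1cc(C(F)(F)F)cc(C(F)(F)F)c1`, has not yet been measured. It arises from compound 1 by trifluoromethyl in place of hydrogen on an aromatic carbon. Among the compounds with values here, this is the same kind of change as the one from compound 2 to compound 3, but not the same: there the new group sat meta to two chloro groups and para to a large group, whereas here it sits meta to a large group and meta to a trifluoromethyl group. Resting on the single precedent, the gain of a 2.6-fold lower number from compound 2 to compound 3 (0.41 log units; beyond the scatter), a step of a 2.0-fold lower number from compound 1 to compound 4 (0.30 log units; within the scatter) is expected for compound 4 in this assay. Within the data shown here, only one earlier example of the change exists and its surroundings differ, so the expectation is held loosely. Compound 4 is therefore estimated at 3000 nM, with a range from 1400 nM to 6500 nM.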

Compound 4, concentration for 50% growth inhibition: 2970 nM
Beside the measured number, compound 4's estimate is 1.0-fold (0.00 log units) above it; measured number inside the range.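

In this assay, trifluoromethyl in place of hydrogen on an aromatic carbon gave a 2.0-fold lower number from compound 1 to compound 4 (0.30 log units; within the scatter), so this step taken alone does not separate compound 4 from compound 1. Set beside the earlier example of the same change, it does not differ in size: the same change on two cores in this assay, a 2.6-fold lower number (0.41 log units; beyond the scatter) from compound 2 to compound 3 and a 2.0-fold lower number (0.30 log units; within the scatter) from compound 1 to compound 4, 1.3-fold (0.11 log units) apart, within the scatter of two such steps This shows that, as far as two examples go, the change gave steps of like size on the two cores, even though the group arrived in different surroundings on the aryl sulfonyl ring; it does not show a rule for the series, since the two examples share the rest of the molecule and only one of the two steps lies beyond the scatter.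

The compounds shown leave open whether a step of this size would survive if the rest of the molecule changed, for instance with a shorter or longer chain or with chlorine or a methoxy group in place of the bromine. They also leave open whether a different group on the same aromatic carbon, such as a nitrile or a methyl group, would give a step like these in this assay.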